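Amide-Side Change from Acetal to Primary Amine

The source may report more compounds than this note shows. Statements on the series, on what has been measured and on what is new or still open speak of the compounds shown alone.

Of the compounds shown here, two of one shared core have been measured in an assay on HL-60 cells for agonist activity at vitamin D3 receptor (Homo sapiens), read by microscopy, with a stated time of 96 h; on this read-out lower numbers stand for an effect already at smaller amounts and higher numbers for an effect only at larger amounts of compound. Compound 1 `CCOC(=O)CN(C)C(=O)c1ccc(C(CC)(CC)c2ccc(OCC(O)C(C)(C)C)c(C)c2)n1CC` gives 210 nM. Compound 2 `CCn1c(C(=O)NCC(OC)OC)ccc1C(CC)(CC)c1ccc(OCC(O)C(C)(C)C)c(C)c1` gives 150 nM, and the difference a 1.4-fold lower number from compound 1 to compound 2 (0.15 log units; within the scatter) shows that swapping one group on the amide carbonyl carbon for another made no difference beyond the scatter. Compound 3 `CCn1c(C(=O)NCCN)ccc1C(CC)(CC)c1ccc(OCC(O)C(C)(C)C)c(C)c1` has not yet been measured. It differs from compound 2 in the same part of the molecule: aminomethyl in place of dimethoxymethyl on a saturated chain carbon bound to an amide-type nitrogen. For the measured compounds named here, the only step that bears on this region, the one from compound 1 to compound 2, was within the scatter, so a change here is expected to leave this assay largely unmoved. For compound 3, the estimated step is a 1.1-fold higher number from compound 2 to compound 3 (0.05 log units; within the scatter), and the expected value is 170 nM, with a range from 60 nM to 500 nM.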

Compound 3, half-maximal effective concentration: 10 nM
Beside the measured number, compound 3's estimate is 17-fold (1.23 log units) above it, outside the stated range (below it).
By their numbers in this assay, from the lowest: compound 3; then compounds 2 and 1 (each within the scatter of the next).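

In this assay, this side chain of the amide turns out to matter a great deal: 2-aminoethyl in place of 2,2-dimethoxyethyl gives a 15-fold lower number from compound 2 to compound 3 (1.18 log units; beyond the scatter), whereas the earlier change on the same amide gave only a 1.4-fold lower number from compound 1 to compound 2 (0.15 log units; within the scatter). Set against the other earlier side chain, (2-aminoethyl)amino in place of ((ethoxycarbonyl)methyl)(methyl)amino gives a 21-fold lower number from compound 1 to compound 3 (1.32 log units; beyond the scatter), so the new side chain stands apart from both earlier ones. Nothing in the data shown gives a reason for this shift.

As far as these compounds go, what remains open is whether the amine end itself or the length of the chain carrying it accounts for the result. A 2-hydroxyethyl group, a 2-(dimethylamino)ethyl group or a longer 3-aminopropyl chain on the same amide would help to separate these possibilities.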